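The source may hold more compounds than are shown below. What is called first, only, known or untested is meant among the compounds shown, and "the series" means these compounds.

Measured so far in a functional assay on QG-56 cells (Homo sapiens) for cytotoxicity, read by MTT assay, with a stated time of 48 h; on this read-out higher numbers stand for weaker inhibition and lower numbers for stronger inhibition:
- compound 1 `COc1cc(/C=C/C(=O)C2=C(/C=C/c3ccc(O)c(OC)c3)NC(=O)NC2c2ccc(C)cc2)ccc1O` gives 100000 nM
- compound 2 `COc1cc(/C=C/C(=O)C2=C(/C=C/c3ccc(O)c(OC)c3)NC(=O)NC2c2ccccc2O)ccc1O` gives 100000 nM
- compound 3 `COc1cc(/C=C/C(=O)C2=C(/C=C/c3ccc(O)c(OC)c3)NC(=O)NC2c2cccc([N+](=O)[O-])c2)ccc1O` gives 25000 nM

Compound 3 holds the lowest number of the three in this assay, and its steps to both other compounds lie beyond the scatter. Compound 4 `COc1cc(/C=C/C(=O)C2=C(/C=C/c3ccc(O)c(OC)c3)NC(=O)NC2c2ccccc2Cl)ccc1O` keeps the shared core and differs from compound 3 in one place, with 2-chlorophenyl in place of 3-nitrophenyl on a saturated ring carbon.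

For the measured compounds named here, three measured steps concern this same ring carbon. Two of them lead to the 3-nitrophenyl group, a 4.0-fold lower number from compound 1 to compound 3 (0.60 log units; beyond the scatter) and a 4.0-fold lower number from compound 2 to compound 3 (0.60 log units; beyond the scatter), and both are modest. The third, no change at the digits printed from compound 1 to compound 2 (within the scatter), shows that the exchange between 4-methylphenyl and 2-hydroxyphenyl leaves the number unchanged. Among these three compounds, then, only compound 3 stands apart, and compound 4 gives up the group that compound 3 alone carries. Going by the values given here, no measured compound bears 2-chlorophenyl, so the expectation remains loose. A modest move toward a higher number is expected, and the expected step is a 2.0-fold higher number from compound 3 to compound 4 (0.30 log units; within the scatter). For compound 4 the estimated value is 50000 nM, with an expected range from 20000 nM to 100000 nM.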

Compound 4, half-maximal inhibitory concentration: 100000 nM
Estimate against measurement, compound 4: 2.0-fold (0.30 log units) below, and the stated range covers the measured number.
By their numbers in this assay, from the lowest: compound 3; then compounds 1, 2 and 4 (each within the scatter of the next).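

In this assay the change to 2-chlorophenyl gives a 4.0-fold higher number from compound 3 to compound 4 (0.60 log units; beyond the scatter) on this saturated ring carbon, so the number rises again when 3-nitrophenyl is exchanged for another substituted phenyl group, this time one that enters with no hydrogen-bond acceptors. The new compound also matches both others, with no change at the digits printed from compound 2 to compound 4 (within the scatter) for chloro in place of hydroxy on an aromatic carbon and no change at the digits printed from compound 1 to compound 4 (within the scatter) for 2-chlorophenyl in place of 4-methylphenyl; 4-methylphenyl, 2-hydroxyphenyl and 2-chlorophenyl thus share one printed number, and among the four compounds only compound 3 stands apart. Nothing measured here bears on why the 3-nitrophenyl compound differs from the other three.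

The compounds shown leave open whether the lower number of compound 3 goes with the nitro group itself or with where that group sits on the phenyl ring. They also leave open whether an amine or a carboxylic acid on the same phenyl ring would lower the number in this assay, or would stay with the other three compounds.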